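The source may hold more compounds than are shown below. What is called first, only, known or untested is meant among the compounds shown, and "the series" means these compounds.

Measured compounds:
Compound 1 `C=C1CC[C@@H]2[C@](C)(CCC[C@]2(C)C(=O)OC)[C@H]1CCc1ccc2c(OCc3ccccc3)ccc(OCc3ccccc3)c2c1`, in a functional assay on A549 cells (Homo sapiens) for cytotoxicity, read by sulforhodamine B assay, with a stated time of 72 h (a lower number here means a stronger inhibitor of growth, a higher number a weaker inhibitor of growth), only a limit: > 5000 nM.
Compound 2 `C=C1[C@H](O)C[C@@H]2[C@](C)(CCC[C@]2(C)C(=O)OC)[C@H]1CCc1ccc2c(OCc3ccccc3)ccc(OCc3ccccc3)c2c1`, in this assay, only a limit: > 4900 nM.
Compound 3 `COC(=O)[C@@]1(C)CCC[C@]2(C)C(CCc3ccc4c(OC(C)=O)ccc(OC(C)=O)c4c3)=C(C)CC[C@@H]12`, in this assay: 240 nM.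

Compound 3 is the only one of the three with a number; the other two sit at limits, the limit of > 5000 nM in this assay, at which 1 of the 3 values shown sits, and (the limit of > 4900 nM in this assay, at which 1 of the 3 values shown sits). The step that the two limits leave unreadable from compound 1 to compound 2, the change being (hydroxy in place of hydrogen on a saturated ring carbon), therefore cannot be read. The difference between the core of compound 1 and the core of compound 3 is not broken down here.

Compound 4 `COC(=O)[C@@]1(C)CCC[C@]2(C)C(CCc3ccc4c(OC(C)=O)ccc(OC(C)=O)c4c3)=C(C)[C@@H](O)C[C@@H]12` has yet to be measured in this assay. It differs from compound 3 by hydroxy in place of hydrogen on a saturated ring carbon. This is the same kind of change as that from compound 1 to compound 2, not the same: in compound 4 the hydroxy stands next to the ring atom that bears a methyl group (1 heavy atom), which the earlier place does not. Since the earlier step is unreadable, the expectation rests on compound 3 alone, at 240 nM. Compound 4 is estimated at 400 nM, a step of a 1.7-fold higher number from compound 3 to compound 4 (0.22 log units; within the scatter), expected to stay within the usual scatter.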

Compound 4, concentration for 50% growth inhibition: 4800 nM
The estimate for compound 4 lay 12-fold (1.08 log units) below the measured number; measured number outside the range, above it.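

In this assay, hydroxy in place of hydrogen on a saturated ring carbon, next to the ring atom that bears a methyl group, gives a 20-fold higher number from compound 3 to compound 4 (1.30 log units; beyond the scatter), so on the core of compound 3 this single change costs much of the growth inhibition. The same kind of change on the core of compound 1 cannot be read, so the compounds do not show whether the effect carries from one core to the other, and compound 2 is known only as a limit: the limit of > 4900 nM in this assay, at which 1 of the 4 values shown sits.

Compound 1 is likewise known only as a limit, not a number: the limit of > 5000 nM in this assay, at which 1 of the 4 values shown sits.

The compounds shown leave open whether the large step belongs to the hydroxy itself or would also appear with a methoxy group, an amine or a ketone on the same ring carbon. They also leave open how the hydroxy would act on the core of compound 3 at another saturated ring carbon.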